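Swapping chloro for cyclopentyl on the fused ring of compound 1

The source may report more compounds than this note shows. Statements on the series, on what has been measured and on what is new or still open speak of the compounds shown alone.

Measured compounds:
- compound 1, `Cc1c(C(=O)Nc2ccc(Oc3ncnc4[nH]cc(-c5ccccc5)c34)c(F)c2)c(=O)c2cc(Cl)ccc2n1C`: 1890 nM
- compound 2, `CCc1ccc2c(c1)c(=O)c(C(=O)Nc1ccc(Oc3ncnc4[nH]cc(-c5ccccc5)c34)cc1F)c(C)n2C`: 30 nM
- compound 3, `CCc1ccc2c(c1)c(=O)c(C(=O)Nc1ccc(Oc3ccnc(C(N)=O)c3)c(F)c1)c(C)n2C`: 4380 nM

These three compounds were tested in an assay on isolated protein for inhibition of tyrosine-protein kinase receptor UFO (Homo sapiens), read by FRET and Z'-LYTE, with a stated time of 1.5 h; a higher number here means a weaker inhibitor, a lower number a stronger inhibitor. Compound 1 sits second highest of the three numbers, which here means second weakest. Its nearest neighbour is compound 3, whose value of 4380 nM lies beyond the usual scatter on the weaker side, while compound 2, at 30 nM, sits far away on the stronger side. Compound 2 differs from compound 1 in more than one place, so its much stronger inhibition cannot be pinned to any single change.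

The next compound, compound 4, `Cc1c(C(=O)Nc2ccc(Oc3ncnc4[nH]cc(-c5ccccc5)c34)c(F)c2)c(=O)c2cc(C3CCCC3)ccc2n1C`, differs from compound 1 in exactly one place: cyclopentyl in place of chloro on an aromatic carbon. Both groups carry no hydrogen-bond donors or acceptors and no charge, so the change is purely one of a small halogen giving way to a larger carbon ring at the same aromatic carbon.

Within the data shown here, with no single-change step available among the measured compounds, the expectation rests on compound 2, whose ethyl group at a comparable part of the shared core goes with a value of 30 nM. A modest improvement is expected for compound 4, so the step of a 2.7-fold lower number from compound 1 to compound 4 (0.43 log units; beyond the scatter) is estimated to be downward and beyond the scatter. Compound 4 is therefore expected to give about 700 nM, within a range of 150 nM to 3000 nM.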

Compound 4, half-maximal inhibitory concentration: 200 nM
Beside the measured number, compound 4's estimate is 3.5-fold (0.54 log units) above it; measured number inside the range.
By their numbers in this assay, from the lowest: compound 2; then compound 4; then compound 1; then compound 3.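

In this assay, among these compounds, the swap of chloro for cyclopentyl gives a 9.5-fold lower number from compound 1 to compound 4 (0.98 log units; beyond the scatter), the first reading of a single change on the shared core, as no earlier pair of compounds differed in only one place. This aromatic carbon therefore accepts a group of five carbon atoms in a ring in place of a single chlorine atom, and the inhibitor becomes stronger rather than weaker. Neither group carries a hydrogen-bond donor, a hydrogen-bond acceptor or a net charge, so the step involves none of these features, but no measurement shown here explains why the larger group goes with the lower number.

With a single step at this carbon, the compounds shown cannot tell whether the trend depends on the size of the group, on its ring, or on something specific to cyclopentyl, and a cyclohexyl ring, a tert-butyl group or a longer straight carbon chain would help separate these. They also leave open how an amine or a carboxylic acid at the same carbon would compare with chloro and cyclopentyl.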